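Ester-to-amide step in a branched dienoate series

This account rests on a few compounds, and the source may have more. Where it says the series, first, only, none or still open, it means among the compounds named here.

Measured so far, in a physicochemical assay for lipophilicity; a higher number here means a more lipophilic compound, a lower number a more polar compound:
compound 1, `COC(=O)/C=C(C)/C=C/CC(C)CCCC(C)C`, gives 6.2
compound 2, `CCOC(=O)/C=C(C)/C=C/CC(C)CCCC(C)(C)C`, gives 7.15

Compound 1 stands lowest of the two numbers. For the measured compounds named here, its nearest neighbour is compound 2, whose reading is higher by a margin beyond the usual scatter; no single-point step between these two is defined, so only the two values themselves speak.

Compound 3, `C=CCNC(=O)/C=C(C)/C=C/CC(C)CCCC(C)C`, has not yet been measured in this assay. It differs from compound 1 as follows: allylamino in place of methoxy on a carbonyl carbon. Cut one bond further out, the same difference reads methoxycarbonyl to allylcarbamoyl.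

Going by the values given here, no measured pair shows this kind of change, so the expectation rests on the structural change alone. A modest step downward, from compound 1 to compound 3, is expected, of a size a number 0.40 log units lower from compound 1 to compound 3 (beyond the scatter), though the outcome could also fall within the scatter of compound 1.

For compound 3 the estimated value in this assay is 5.8, expected to lie between 5.1 and 6.5.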

Compound 3, partition coefficient: 5.23
For compound 3 the middle estimate is 0.57 log units above the measured one; the range from low to high includes it.
By their numbers in this assay, from the lowest: compound 3; then compound 1; then compound 2.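

In this assay, allylamino in place of methoxy on a carbonyl carbon gives the only single-place step available in the series, a number 0.97 log units lower from compound 1 to compound 3 (beyond the scatter), so this position is shown to respond clearly to a change of group. The number goes down even though the entering allylamino has 4 heavy atoms against 2 for methoxy, so in this one pair the reading does not track the heavy-atom count of the group; the exchange also swaps 1 hydrogen-bond acceptor on the leaving group for 1 hydrogen-bond donor on the entering one. Nothing at hand bears on which feature of the exchange accounts for the step.

From the compounds shown here alone, whether the step belongs to the amide nitrogen with its hydrogen or to the allyl part stays open: propylamino, or dimethylamino with no amide hydrogen, on the same carbonyl carbon would separate the two. Also open, going by these compounds, are a carboxylic acid at this place and whether the same exchange on the core of compound 2 gives a step of similar size.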